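A Second Methyl on the Aromatic Ring of Compound 2

The source may report more compounds than this note shows. Statements on the series, on what has been measured and on what is new or still open speak of the compounds shown alone.

Compound 1 `COc1cccc2c1CCC=C2c1c[nH]cn1` and compound 2 `Cc1cccc2c1CCC=C2c1c[nH]cn1` share one core and differ only in a single group on an aromatic carbon. In an assay on cell membranes for displacement of a labelled ligand from Adrenergic receptor alpha-1 (Rattus norvegicus) (a higher number here means a weaker inhibitor, a lower number a stronger inhibitor), compound 1 gives 2970 nM, while compound 2 gives 992 nM. The step of a 3.0-fold lower number from compound 1 to compound 2 (0.48 log units; beyond the scatter) shows that methyl in place of methoxy lowered the number. For the measured compounds named here, compound 2 therefore stands at the lowest of the two numbers measured so far, with compound 1 as its only neighbour.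

Compound 3 `Cc1cc(C)c2c(c1)C(c1c[nH]cn1)=CCC2` has not yet been measured. It differs from compound 2 by methyl in place of hydrogen on an aromatic carbon, a further methyl on an aromatic carbon, placed meta to a fused ring, meta to the existing methyl group and para to a fused ring. Going by the values given here, no measured step exchanges hydrogen for methyl at such a place; the only measured step, a 3.0-fold lower number from compound 1 to compound 2 (0.48 log units; beyond the scatter), concerns a different exchange at a different carbon and offers no direct guide. The expected change in this assay is therefore none beyond the scatter, with the direction left open. Compound 3 is estimated at 800 nM, within a range of 300 nM to 2500 nM, corresponding to an expected step of a 1.2-fold lower number from compound 2 to compound 3 (0.09 log units; within the scatter).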

Compound 3, inhibition constant: 2960 nM
Compound 3: the middle estimate sits 3.7-fold (0.57 log units) below what was measured, outside the stated range (above it).
By their numbers in this assay, from the lowest: compound 2; then compounds 3 and 1 (each within the scatter of the next).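

In this assay, placing a methyl group on this aromatic carbon, meta to a fused ring and meta to the existing methyl group, gives a 3.0-fold higher number from compound 2 to compound 3 (0.47 log units; beyond the scatter), so a single added carbon at this position moves the number beyond the scatter. Set beside the earlier step, a 3.0-fold lower number from compound 1 to compound 2 (0.48 log units; beyond the scatter), this shows that changes on the same aromatic ring can move the number in either direction: there it fell, while here it rose, pointing to a weaker inhibitor. Nothing shown here gives a reason for this rise.

Only hydrogen and methyl are shown at this carbon, so it remains open whether the rise is particular to methyl or would also follow a different group there, such as a fluorine atom, a hydroxyl group or an amine. Going by these compounds, it also remains open whether the same added methyl would raise the number to a similar extent in a compound carrying methoxy, as compound 1 does, rather than the existing methyl group.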